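The compounds below may be only part of what the source reports. "The series", "measured", "known", "first", "only" and "open" are said of these compounds alone.

Measured in a functional assay on DU-145 cells (Homo sapiens) for inhibition, read by trypan blue exclusion, with a stated time of 96 h; on this read-out lower numbers stand for stronger inhibition of growth and higher numbers for weaker inhibition of growth:
- compound 1 `O=C(/C(=C\c1ccc(O)cc1O)S(=O)(=O)c1ccccc1Br)c1ccc(Br)cc1`: > 100000 nM (a limit, not a number)
- compound 2 `Cc1ccsc1/C=C(\C(=O)c1ccc([N+](=O)[O-])cc1)S(=O)(=O)Cc1ccc(Cl)cc1`: 1000 nM
- compound 3 `O=C(/C(=C\c1ccc(Br)cc1)SCc1ccc(F)cc1)c1ccc(Br)cc1`: 25000 nM

Compound 1 is known only through a limit, (the limit of > 100000 nM in this assay, at which 1 of the 3 values shown sits). Compound 4 `O=C(/C(=C\c1ccc(Br)cc1)S(=O)(=O)c1ccccc1Br)c1ccc(Br)cc1` is not yet measured, and it differs from compound 1 by 4-bromophenyl in place of 2,4-dihydroxyphenyl on a double-bonded chain carbon bound to a double-bonded chain carbon. For the measured compounds named here, no measured pair isolates this change, so the expectation rests on the values alone. Stronger inhibition of growth is expected, since compound 3 is the only measured compound with 4-bromophenyl at this place and gives 25000 nM. The expected size is an at least 5.0-fold lower number from compound 1 to compound 4 (0.69 log units; beyond the scatter). For compound 4 the estimated value is 20000 nM, with an expected range of 4000 nM to 90000 nM.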

Compound 4, concentration for 50% growth inhibition: 1000 nM
Compound 4: middle estimate off by 20-fold (1.30 log units), on the high side; the whole stated range lies above it.
By their numbers in this assay, from the lowest: compounds 2 and 4 (each within the scatter of the next); then compound 3. At a limit, above all of these: compound 1.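

In this assay, 4-bromophenyl in place of 2,4-dihydroxyphenyl on a double-bonded chain carbon bound to a double-bonded chain carbon gives an at least 100-fold lower number from compound 1 to compound 4 (2.00 log units; beyond the scatter). For the compounds shown here, this is the first comparison of this place on an otherwise unchanged core, and it shows that the group here alone separates a compound at the limit from one with a measured value. The size of the step is a minimum only: the limit of > 100000 nM in this assay, at which 1 of the 4 values shown sits.

The compounds shown do not separate the loss of the two hydroxyl groups from the gain of bromine. Going by these compounds, whether a phenyl ring bearing an amine or a carboxylic acid at this place keeps the growth inhibition of compound 4 also remains open.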